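A ring swap on the sulfonyl sulfur

The source may report more compounds than this note shows. Statements on the series, on what has been measured and on what is new or still open speak of the compounds shown alone.

- compound 1 `O=C(Nc1ccc(F)c(Cl)c1)c1ccc(F)c(S(=O)(=O)N2CCSCC(O)C2)c1`: 19000 nM
- compound 2 `O=C(Nc1ccc(F)c(Cl)c1)c1ccc(F)c(S(=O)(=O)N2CCCCC(O)CC2)c1`: 24000 nM

Both compounds were tested in an ADME assay on HepG2 2.2.15 cells (Homo sapiens) for cytotoxicity, read by luminescence, with a stated time of 3 days; on this read-out lower numbers stand for higher toxicity in this test and higher numbers for lower toxicity in this test. Compound 2, at 24000 nM, stands within the scatter of compound 1, so the two cannot be ranked.

Compound 3 `COC1COCCN(S(=O)(=O)c2cc(C(=O)Nc3ccc(F)c(Cl)c3)ccc2F)C1` keeps the shared core and alters only the ring group: a group of 9 heavy atoms (6 carbon, 1 nitrogen, 2 oxygen; one seven-membered non-aromatic ring with 2 hetero atoms) in place of a group of 9 heavy atoms (7 carbon, 1 nitrogen, 1 oxygen; one eight-membered non-aromatic ring with 1 hetero atom), on a sulfonyl sulfur. The entering group is 6-methoxy-1,4-oxazepan-4-yl, and it sits on a sulfonyl sulfur, as the group it replaces does.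

For the measured compounds named here, one measured step bears on this change: a 1.3-fold higher number from compound 1 to compound 2 (0.10 log units; within the scatter). That step also exchanged one ring on a sulfonyl sulfur for another, and it stayed within the scatter. However, both of those compounds carry a hydrogen-bond donor in the ring group, whereas the entering group has none, so no measured pair tests this difference. A step beyond the scatter is therefore not expected, though the uncertainty is wide.

For compound 3 the expected value is 22000 nM, with an estimated range of 10000 nM to 50000 nM. The expected change is a 1.1-fold lower number from compound 2 to compound 3 (0.04 log units; within the scatter).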

Compound 3, half-maximal cytotoxic concentration: 8700 nM
Estimate against measurement, compound 3: 2.5-fold (0.40 log units) above; measured number below the stated range.
By their numbers in this assay, from the lowest: compound 3; then compounds 1 and 2 (each within the scatter of the next).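

In this assay the group 6-methoxy-1,4-oxazepan-4-yl on the sulfonyl sulfur gives a 2.8-fold lower number from compound 2 to compound 3 (0.44 log units; beyond the scatter) and a 2.2-fold lower number from compound 1 to compound 3 (0.34 log units; beyond the scatter) and so shows, in two modest steps, that a ring swap at this place can move the number beyond the scatter, towards higher toxicity in this test, which the earlier swap between the first two compounds did not do. Ring identity at this place therefore cannot be treated as neutral for this read-out, although compound 3 is the only compound shown that stands apart. The change from compound 2 replaces a group with 1 hydrogen-bond donor by one with 0 and also alters the ring and its hetero atoms, and nothing measured here explains the shift.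

These compounds leave open which part of the change matters, the methoxy group or the ring that carries it. A compound bearing 6-hydroxy-1,4-oxazepan-4-yl on the sulfonyl sulfur would differ from compound 3 at the methoxy group alone and would help to separate the two.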